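A few compounds are considered here, and "the series" means these few. Any claim that something is new, unique, unknown or untested is made for them only; others in the source may bear on it.

Of the compounds shown here, three that share one core have been tested in a functional assay on HepG2 cells (Homo sapiens) for antiproliferative activity, read by sulforhodamine B assay, with a stated time of 48 h; a lower number here means a stronger inhibitor, a higher number a weaker inhibitor. Compound 1 `O=S(=O)(Nc1nccs1)c1ccc(N/C(S)=N\c2ccnc3cc(C(F)(F)F)ccc23)cc1` gives 28200 nM, compound 2 `O=S(=O)(Nc1ccccn1)c1ccc(N/C(S)=N\c2ccnc3cc(C(F)(F)F)ccc23)cc1` gives 28000 nM, and compound 3 `Cc1cc(C)nc(NS(=O)(=O)c2ccc(N/C(S)=N\c3ccnc4cc(C(F)(F)F)ccc34)cc2)n1` gives 72200 nM. Compound 3 therefore carries the highest number of the three and is the weakest inhibitor: the step of a 2.6-fold higher number from compound 1 to compound 3 (0.41 log units; beyond the scatter) and the step of a 2.6-fold higher number from compound 2 to compound 3 (0.41 log units; beyond the scatter) are both modest yet beyond the scatter, while the step of a 1.0-fold lower number from compound 1 to compound 2 (0.00 log units; within the scatter) lies within it. Compound 4 `COc1ncnc(NS(=O)(=O)c2ccc(N/C(S)=N\c3ccnc4cc(C(F)(F)F)ccc34)cc2)c1OC` has not yet been measured. It differs from compound 3 in one place: 5,6-dimethoxypyrimidin-4-yl in place of 4,6-dimethylpyrimidin-2-yl on a sulfonamide nitrogen. For the measured compounds named here, no measured step exchanges one pyrimidine ring for another, so nothing bears directly on this change; the three steps seen only show that swapping the ring on the sulfonamide nitrogen shifts this assay by at most a modest amount. A step of similar modest size is expected here, most likely toward a somewhat lower number, estimated as a 1.4-fold lower number from compound 3 to compound 4 (0.16 log units; within the scatter). Compound 4 is accordingly expected to give about 50000 nM, within a range from 20000 nM to 150000 nM.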

Compound 4, half-maximal inhibitory concentration: 77300 nM
Beside the measured number, compound 4's estimate is 1.5-fold (0.19 log units) below it, and the stated range covers the measured number.
By their numbers in this assay, from the lowest: compounds 2 and 1 (each within the scatter of the next); then compounds 3 and 4 (each within the scatter of the next).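

In this assay, exchanging one pyrimidine ring for another on the sulfonamide nitrogen leaves the number unchanged within the scatter (a 1.1-fold higher number from compound 3 to compound 4 (0.03 log units; within the scatter)), although the 5,6-dimethoxypyrimidin-4-yl group has more heavy atoms and more hydrogen-bond acceptors than the 4,6-dimethylpyrimidin-2-yl group. For the compounds shown here, compound 4 also sits modestly above the two compounds without a pyrimidine ring (a 2.8-fold higher number from compound 2 to compound 4 (0.44 log units; beyond the scatter); a 2.7-fold higher number from compound 1 to compound 4 (0.44 log units; beyond the scatter)), so all four compounds now fall into two groups, with both pyrimidine compounds carrying the higher numbers and no compound going against this split. Nothing measured here explains this split.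

Compound 4 alters both the ring's attachment point and its substituents, so the effect of each remains unseparated, and a 4,6-dimethoxypyrimidin-2-yl group would address this. From the compounds shown here alone, how a non-aromatic group on this nitrogen, such as an acetyl group or a short alkyl chain, would behave also remains open.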